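A few compounds are considered here, and "the series" means these few. Any claim that something is new, unique, unknown or untested is made for them only; others in the source may bear on it.

Measured compounds in this study:

Compound 1 `CCc1ccc(S(=O)(=O)N2CCC(N3CCC(C)CC3)CC2)cc1` gives > 5000 nM in a functional assay on DLD-1 cells (Homo sapiens) for antiproliferative activity, read by CellTiter-Glo, with a stated time of 72 h (a lower number here means a stronger inhibitor, a higher number a weaker inhibitor), which is a limit of the assay and not a number.
Compound 2 `Cc1noc(C)c1S(=O)(=O)N1CCC(N2CCC(C)CC2)CC1` gives > 5000 nM in this assay, again a limit rather than a number.
Compound 3 `CC1CCN(C2CCN(S(=O)(=O)c3ccc(Cl)c(Cl)c3)CC2)CC1` gives 2.9 nM in this assay.

Compound 1 therefore sits at the limit of > 5000 nM in this assay, at which 2 of the 3 values shown sit, so no number is known for it, only that it is a weak inhibitor. The measured steps all exchange the whole group on the sulfonyl sulfur: a step that the two limits leave unreadable from compound 1 to compound 2, while an at least 1700-fold lower number from compound 1 to compound 3 (3.23 log units; beyond the scatter) and an at least 1700-fold lower number from compound 2 to compound 3 (3.23 log units; beyond the scatter) show how far a different aryl group can move the number. Compound 4 `CC1CCN(C2CCN(S(=O)(=O)c3ccc(-c4ccccc4)cc3)CC2)CC1` differs from compound 1 by phenyl in place of ethyl on an aromatic carbon. Among the compounds with values here, none of the measured steps keeps the phenyl and changes only its substituent, so none bears directly on this change; they show only that the group on the sulfonyl sulfur can shift the number by a large amount. Within the data shown here, with no closer precedent, compound 4 is expected to remain a weak inhibitor, with an estimated 3000 nM (range 200 nM to 50000 nM). The step of an at least 1.6-fold lower number from compound 1 to compound 4 (0.22 log units; that floor lies within the scatter) is thus expected to be small, with a real chance that only a limit is reported again.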

Compound 4, half-maximal inhibitory concentration: 258 nM
Beside the measured number, compound 4's estimate is 12-fold (1.07 log units) above it; the range from low to high includes it.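

Until now every measured step exchanged the whole group on the sulfonyl sulfur; here the benzene ring attached to that sulfur stays, and only its substituent changes. Phenyl in place of ethyl on this aromatic carbon gives an at least 19-fold lower number from compound 1 to compound 4 (1.28 log units; beyond the scatter) in this assay, so a change at this one position is enough to move the number by a large amount. That size is only a floor, because the value for compound 1 is a limit and not a number: the limit of > 5000 nM in this assay, at which 2 of the 4 values shown sit.

The compounds shown leave open whether a ring is needed at this position or a longer chain such as butyl would serve as well. They also leave open what an amine or a carboxylic acid on the same carbon would do to the number.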